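The source may report more compounds than this note shows. Statements on the series, on what has been measured and on what is new or still open speak of the compounds shown alone.

Working notes on the series.

Compound 1 `CC[C@](C)(O)CC(=O)O[C@H](CC=C(C)C)C1=CC(=O)c2c(O)ccc(O)c2C1=O` is the reference point. In a functional assay on DU-145 cells (Homo sapiens) for cytotoxicity, read by MTT assay (on this read-out higher numbers stand for weaker inhibition and lower numbers for stronger inhibition), compound 1 gives 20500 nM, the highest of the two numbers recorded in this assay; its nearest neighbour is compound 3 `CC(=O)OC(C)CO[C@H](CC=C(C)C)C1=CC(=O)c2c(O)ccc(O)c2C1=O`, which gives 16600 nM, so that a 1.2-fold lower number from compound 1 to compound 3 (0.09 log units; within the scatter). Compound 2 `CCCCCCC(C)(O)CC(=O)O[C@H](CC=C(C)C)C1=CC(=O)c2c(O)ccc(O)c2C1=O` reaches only a limit of this assay, > 100000 nM, and no number is available for it (the limit of > 100000 nM in this assay, at which 1 of the 3 values shown sits).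

Compound 4 `CCC(O)(CC)CC(=O)O[C@H](CC=C(C)C)C1=CC(=O)c2c(O)ccc(O)c2C1=O` has not yet been measured. It differs from compound 1 by 1-ethyl-1-hydroxypropyl in place of 1-hydroxy-1-methylpropyl on a saturated chain carbon bound to a carbonyl carbon.

For the measured compounds named here, the step that bears on this change is the one from compound 1 to compound 2, which also lengthens the chain on the saturated chain carbon bound to the carbonyl carbon and gives an at least 4.8-fold higher number from compound 1 to compound 2 (0.68 log units; beyond the scatter). The change to compound 4 is a smaller addition of carbon than that step, so a weakening smaller than from compound 1 to compound 2 is expected, probably at the edge of the scatter. Compound 4 is therefore expected to give 30000 nM in this assay, with a range of 12000 nM to 80000 nM, meaning an expected step of a 1.5-fold higher number from compound 1 to compound 4 (0.17 log units; within the scatter).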

Compound 4, half-maximal inhibitory concentration: 67000 nM
Compound 4: middle estimate off by 2.2-fold (0.35 log units), on the low side, within the range that was stated.
By their numbers in this assay, from the lowest: compounds 3 and 1 (each within the scatter of the next); then compound 4. At a limit, above all of these: compound 2.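

The swap of 1-hydroxy-1-methylpropyl for 1-ethyl-1-hydroxypropyl on a saturated chain carbon bound to a carbonyl carbon gives, in this assay, a 3.3-fold higher number from compound 1 to compound 4 (0.51 log units; beyond the scatter), so this position responds to a group of 6 heavy atoms in place of 5, a far smaller change than the one to 1-hydroxy-1-methylheptyl. Compound 4 also stands apart from compound 3, with a 4.0-fold higher number from compound 3 to compound 4 (0.61 log units; beyond the scatter), a separation that compound 1 does not show against compound 3. Whether 1-hydroxy-1-methylheptyl weakens the number further than 1-ethyl-1-hydroxypropyl stays unsettled, with an at least 1.4-fold lower number from compound 2 to compound 4 (0.17 log units; that floor lies within the scatter), and compound 2 stands at a limit of the assay, not at a number: the limit of > 100000 nM in this assay, at which 1 of the 4 values shown sits.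

The change to compound 4 also removes the defined stereocentre of the leaving group, so the compounds shown cannot separate the effect of the added carbon from that of the lost stereocentre. They also leave open how a shorter 1-hydroxyethyl group, or a group carrying an amine or a carboxylic acid in place of the hydroxyl, would read at this place in this assay.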